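Carbamate series: trifluoromethyl added beside the chloro of compound 1

A few compounds are considered here, and "the series" means these few. Any claim that something is new, unique, unknown or untested is made for them only; others in the source may bear on it.

Compound 1 `COc1ccc(N2CCN(CCC(OC(N)=O)c3ccc(Cl)cc3)CC2)cc1` holds the lowest of the three numbers in a functional assay on the whole organism for inhibition, with Mus musculus as the target, in the writhing test, with a stated time of 1 h, at a dose of 10 mg/kg by the oral route (a lower number here means less inhibition, a higher number more inhibition at the dose given (going by the name of the read-out)), giving 51%; compound 2 `COc1ccc(C(CCN2CCN(c3ccc(OC)cc3)CC2)OC(N)=O)cc1` gives 53% and compound 3 `COc1ccc(N2CCN(CCC(OC(N)=O)c3ccc(C)c(C)c3)CC2)cc1` gives 58%, both within the scatter of compound 1. The steps from compound 1 alter the aryl group on the saturated chain carbon bound to an oxygen next to a carbonyl group: a number 2 percentage points higher from compound 1 to compound 2 (within the scatter) and a number 7 percentage points higher from compound 1 to compound 3 (within the scatter). Between the other two, a number 5 percentage points higher from compound 2 to compound 3 (within the scatter). Compound 4 `COc1ccc(N2CCN(CCC(OC(N)=O)c3ccc(Cl)c(C(F)(F)F)c3)CC2)cc1` differs from compound 1 by trifluoromethyl in place of hydrogen on an aromatic carbon. Going by the values given here, no measured step adds a group there, and every step on this aryl group stays within the scatter, so nothing beyond the scatter is expected in this assay. For compound 4 the expected step is a number 4 percentage points higher from compound 1 to compound 4 (within the scatter). The estimate for compound 4 is 55%, ranging from 40% to 70%.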

Compound 4, a percentage reported as inhibition, in the whole organism at one dose (the size of the read-out at that dose, not a potency): 46%
Compound 4: middle estimate off by 9 percentage points, on the high side; measured number inside the range.
By their numbers in this assay, from the lowest: compounds 4, 1, 2 and 3 (each within the scatter of the next, the first and the last beyond it).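

In this assay, trifluoromethyl in place of hydrogen on an aromatic carbon, ortho to a chloro group, gives a number 5 percentage points lower from compound 1 to compound 4 (within the scatter), so this position accepts a group of 4 heavy atoms with a step that stays within the scatter. The earlier steps shown here exchanged the whole aryl group, whereas this one keeps the chloro group and adds to the ring. Nothing available explains the size or direction of this step.

On these data alone, whether an amine or a methoxy group at this position would also stay within the scatter remains open. So does whether trifluoromethyl gives a similar step without the chloro group.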